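Ring-closed amino substituent on a chlorinated benzamide

A few compounds are considered here, and "the series" means these few. Any claim that something is new, unique, unknown or untested is made for them only; others in the source may bear on it.

Three compounds share one core and differ only in the amino group that sits on the chlorinated ring. Compound 1 `CN(C)c1ccc(C(=O)N2CCCCc3ccccc32)c(Cl)c1` carries a dimethylamino group and gives 18 nM in an assay on HeLa cells for binding affinity to Vasopressin V2 receptor (Homo sapiens); a higher number here means a weaker inhibitor, a lower number a stronger inhibitor. Compound 2 `CCN(CC)c1ccc(C(=O)N2CCCCc3ccccc32)c(Cl)c1` carries a diethylamino group and gives 19 nM. Compound 3 `C=CCNc1ccc(C(=O)N2CCCCc3ccccc32)c(Cl)c1` carries an allylamino group and gives 5.9 nM, the lowest of the three numbers; its nearest neighbour is compound 1, the furthest compound 2.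

Compound 4 `CC1CCN(c2ccc(C(=O)N3CCCCc4ccccc43)c(Cl)c2)C1` is the next step: 3-methylpyrrolidin-1-yl in place of allylamino on an aromatic carbon. The entering group, like dimethylamino and diethylamino, has no hydrogen-bond donor, whereas allylamino has one. Among the compounds with values here, the steps that bear on this are a 3.1-fold lower number from compound 1 to compound 3 (0.48 log units; beyond the scatter) and a 3.2-fold lower number from compound 2 to compound 3 (0.51 log units; beyond the scatter), both modest and both in favour of the allylamino compound. The step of a 1.1-fold higher number from compound 1 to compound 2 (0.02 log units; within the scatter) shows that enlarging the donor-free amino group from dimethyl to diethyl changed nothing beyond the scatter. The expectation for compound 4 is therefore a modest rise back toward the numbers of compound 1 and compound 2, that is a 2.5-fold higher number from compound 3 to compound 4 (0.41 log units; beyond the scatter). The estimate for compound 4 in this assay is 15 nM, with a range from 6 nM to 40 nM.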

Compound 4, half-maximal inhibitory concentration: 51 nM
The estimate for compound 4 lay 3.4-fold (0.53 log units) below the measured number; measured number outside the range, above it.
By their numbers in this assay, from the lowest: compound 3; then compounds 1 and 2 (each within the scatter of the next); then compound 4.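

In this assay, replacing allylamino with 3-methylpyrrolidin-1-yl gives an 8.6-fold higher number from compound 3 to compound 4 (0.94 log units; beyond the scatter) and so takes the number past those of the two open-chain dialkylamino compounds, not merely back to them. The ring-bearing compound also stands apart from each of those compounds, with a 2.7-fold higher number from compound 2 to compound 4 (0.43 log units; beyond the scatter) and with a 2.8-fold higher number from compound 1 to compound 4 (0.45 log units; beyond the scatter) as well, so the absence of a hydrogen-bond donor does not by itself fix the number at this position, even though all three donor-free compounds sit above compound 3. This step changes the donor, the ring, the double bond and the size of the group together, and no measurement shown here accounts for the rise.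

Still open, on these data alone, is whether an unsubstituted pyrrolidin-1-yl group would sit with compound 4 or with compound 1, which would separate the effect of the ring from that of its methyl group. A propylamino group, which keeps the amine hydrogen but has no double bond, would likewise show whether compound 3 owes its low number to that hydrogen or to the allyl chain.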